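From a Fluorophenyl to a Pyridinylmethyl Sulfonamide

The compounds below may be only part of what the source reports. "The series", "measured", "known", "first", "only" and "open" are said of these compounds alone.

Of the compounds shown here, three built on one shared core have been measured in a physicochemical assay for lipophilicity, at pH 7.4; on this read-out higher numbers stand for higher lipophilicity and lower numbers for lower lipophilicity. Compound 1 `CC(C)CN(c1ccc(N(C)C)cc1)S(=O)(=O)c1ccc2c(c1)C(O)CC(C1CCOCC1)O2` gives 3.51. Compound 2 `CC(C)CN(c1ccc(C#N)cc1)S(=O)(=O)c1ccc2c(c1)C(O)CC(C1CCOCC1)O2` gives 3.07, and compound 3 `CC(C)CN(c1cccc(F)c1)S(=O)(=O)c1ccc2c(c1)C(O)CC(C1CCOCC1)O2` gives 3.39. Compound 3 stands second highest of the three: its nearest neighbour is compound 1, a gap within the scatter, and its furthest is compound 2, a gap beyond it. The measured steps are a number 0.44 log units lower from compound 1 to compound 2 (beyond the scatter) and a number 0.32 log units higher from compound 2 to compound 3 (beyond the scatter), while a number 0.12 log units lower from compound 1 to compound 3 (within the scatter).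

Compound 4 `CCS(=O)(=O)c1ccc(CN(CC(C)C)S(=O)(=O)c2ccc3c(c2)C(O)CC(C2CCOCC2)O3)nc1` differs from compound 3 in one place: (5-(ethylsulfonyl)pyridin-2-yl)methyl in place of 3-fluorophenyl on a sulfonamide nitrogen. The measured steps that bear on this are the two that exchange the group on the sulfonamide nitrogen, a number 0.32 log units higher from compound 2 to compound 3 (beyond the scatter) and a number 0.44 log units lower from compound 1 to compound 2 (beyond the scatter); both were modest and both kept a six-membered aromatic ring of carbon only. The present change exchanges that ring for a larger group with a ring holding a hetero atom and with acceptors the leaving group lacks, as the counted difference shows. Compound 4 is therefore expected to come out lower, by a number 1.49 log units lower from compound 3 to compound 4 (beyond the scatter), a step larger than either measured one. The estimate for compound 4 in this assay is 1.9, with a range from 1.2 to 2.6.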

Compound 4, distribution coefficient: 1.42
The estimate for compound 4 lay 0.48 log units above the measured number; the range from low to high includes it.
By their numbers in this assay, from the lowest: compound 4; then compound 2; then compounds 3 and 1 (each within the scatter of the next).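

In this assay the entering (5-(ethylsulfonyl)pyridin-2-yl)methyl group gave a number 1.97 log units lower from compound 3 to compound 4 (beyond the scatter) and a number 1.65 log units lower from compound 2 to compound 4 (beyond the scatter) and also a number 2.09 log units lower from compound 1 to compound 4 (beyond the scatter) and all three steps are large, while no earlier exchange of the group on the sulfonamide nitrogen went beyond modest. This place on the sulfonamide nitrogen can therefore carry a far wider span of this read-out than the three substituted phenyl groups had shown, and compound 4 stands alone at the low end, beyond the scatter from each of the others. The change bundles several counted differences, among them a six-membered aromatic ring with 1 hetero atom, 12 heavy atoms in place of 7 and 3 hydrogen-bond acceptors in place of 0, and no supporting measurement separates these differences or accounts for the size of the step.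

The compounds shown leave open how the step divides between the ethylsulfonyl group, the ring nitrogen and the methyl link to the sulfonamide nitrogen. A plain benzyl group, a pyridin-2-ylmethyl group without the ethylsulfonyl, or a (5-(ethylsulfonyl)phenyl)methyl group would each isolate one of these parts, and an amine or a carboxylic acid in place of the ethylsulfonyl remains equally unexplored here.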